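This account rests on a few compounds, and the source may have more. Where it says the series, first, only, none or still open, it means among the compounds named here.

Values in an ADME assay on MT2 cells (Homo sapiens) for cytotoxicity, read by XTT assay, with a stated time of 4 days; a higher number here means that more compound is tolerated, a lower number that less compound is tolerated:
compound 1 `Cc1ccc(NC(=O)C(=O)NC(c2nc(C)c(CCO)s2)C2CCCCN2)c(F)c1`: > 78800 nM
compound 2 `Cc1ccc(NC(=O)C(=O)NC(c2nc(C)c(CO)s2)C2CCCCN2)c(F)c1`: > 109000 nM
compound 3 `CC(=O)N1CCCCC1C(NC(=O)C(=O)Nc1ccc(Cl)cc1)c1nc(C)c(CCO)s1`: > 84000 nM

Compound 1 gives > 78800 nM, which is a limit and not a number. Compound 2 gives > 109000 nM, which is also a limit. Compound 3 gives > 84000 nM, again a limit. Compound 1 therefore stands among limits only, with no exact number beside it.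

Compound 4 `Cc1nc(C(NC(=O)C(=O)Nc2ccc(F)c(Cl)c2)C2CCCCN2)sc1CCO` keeps the core of compound 1 and changes only the group on the amide-type nitrogen: 3-chloro-4-fluorophenyl in place of 2-fluoro-4-methylphenyl on an amide-type nitrogen. Among the compounds with values here, the single measured step is a step that the two limits leave unreadable from compound 1 to compound 2. That step puts hydroxy in place of hydroxymethyl, so it lies elsewhere in the structure, and it offers no size to carry over. Within the data shown here, no measured step covers the new change, so no shift beyond the scatter is expected in this assay. The expected change is an at least 1.0-fold lower number from compound 1 to compound 4 (0.02 log units; that floor lies within the scatter). A reported limit would be no surprise. For compound 4 the estimated value is 75000 nM, with an expected range from 30000 nM to 115000 nM.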

Compound 4, half-maximal cytotoxic concentration: 94700 nM
Compound 4: the middle estimate sits 1.3-fold (0.10 log units) below what was measured, and the stated range covers the measured number.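

In this assay, within the data shown here, compound 1 gives only the limit > 78800 nM and so no step to compound 4 can be read. The compounds shown leave open how far putting 3-chloro-4-fluorophenyl in place of 2-fluoro-4-methylphenyl moves the tolerated concentration, and where compound 1 itself becomes toxic to these cells.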